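Anilide substituent changes on a cytotoxicity read-out

The compounds below may be only part of what the source reports. "The series", "measured", "known", "first", "only" and "open" are said of these compounds alone.

Measured compounds in an ADME assay on TZM-b1 cells (Homo sapiens) for cytotoxicity, read by XTT assay, with a stated time of 3 days; on this read-out lower numbers stand for higher toxicity in this test and higher numbers for lower toxicity in this test:
Compound 1 `Cc1ccc(NC(=O)C(=O)NC(c2nc(C)c(CO)s2)C2CCCCN2)c(F)c1` gives > 88000 nM, a limit of the assay.
Compound 2 `Cc1nc(C(NC(=O)C(=O)Nc2ccc(Cl)c(F)c2)C2CCCCN2)sc1CO` gives 58400 nM.
Compound 3 `CC(=O)c1ccc(NC(=O)C(=O)NC(c2nc(C)c(CO)s2)C2CCCCN2)cc1` gives > 86000 nM, a limit of the assay.

Compound 3 thus stands at the limit of > 86000 nM in this assay, at which 1 of the 3 values shown sits; of the three values shown, one other is a limit as well, and only compound 2 gives a number. Compound 4 `Cc1nc(C(NC(=O)C(=O)Nc2ccc(F)cc2)C2CCCCN2)sc1CO` differs from compound 3 by fluoro in place of acetyl on an aromatic carbon. Among the measured compounds shown here, the steps that bear on this change both alter the same anilide ring: an at least 1.4-fold higher number from compound 2 to compound 3 (0.16 log units; that floor lies within the scatter), and a step that the two limits leave unreadable from compound 1 to compound 3. Neither shows a readable effect of the anilide substituent in this assay. The step of an at least 1.0-fold lower number from compound 3 to compound 4 (0.03 log units; that floor lies within the scatter) is therefore expected to stay within the scatter. Compound 4 is expected at 80000 nM, in the range 40000 nM to 130000 nM, with a fair chance that only a limit is reported.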

Compound 4, half-maximal cytotoxic concentration: > 90000 nM
Compound 4: a limit, no number; the forecaster's own chance of this, stated with the estimate: 55%; middle value at least 1.1-fold (0.05 log units) away from the limit.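

In this assay compound 4, with the much smaller fluoro in place of acetyl on this aromatic carbon, also gives only a limit of the assay: the limit of > 90000 nM in this assay, at which 1 of the 4 values shown sits. Among the compounds shown here, the only readable new step is an at least 1.5-fold higher number from compound 2 to compound 4 (0.18 log units; that floor lies within the scatter). The steps from compound 3 to compound 4 and from compound 1 to compound 4 cannot be read.

From the compounds shown here alone, whether compound 1, compound 3 and compound 4 truly differ remains open. Also open, going by these compounds, is how an amine or a carboxylic acid at this aromatic carbon would read.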